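The source may hold more compounds than are shown below. What is called first, only, known or untested is meant among the compounds shown, and "the series" means these compounds.

Measured so far in a functional assay on A549 cells (Homo sapiens) for cytotoxicity, read by sulforhodamine B assay, with a stated time of 48 h; a higher number here means a weaker inhibitor, a lower number a stronger inhibitor:
compound 1, `COc1ccc2c(c1)c(/C=C1/C(=O)Nc3ccc(F)cc31)cn2Cc1cn([C@@H]2O[C@H](COC(C)=O)[C@@H](OC(C)=O)[C@H](OC(C)=O)[C@H]2OC(C)=O)nn1`, gives only a limit, > 200000 nM.
compound 2, `CC(=O)OC[C@H]1O[C@@H](n2cc(CN3C(=O)/C(=C\c4ccccc4)c4ccccc43)nn2)[C@H](OC(C)=O)[C@@H](OC(C)=O)[C@@H]1OC(C)=O`, gives 17900 nM.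
compound 3, `CC(=O)OC[C@H]1O[C@@H](n2cc(CN3C(=O)/C(=C/c4ccccc4)c4ccccc43)nn2)[C@H](OC(C)=O)[C@@H](OC(C)=O)[C@@H]1OC(C)=O`, gives 20600 nM.

Compound 3 stands with compound 2: the step of a 1.2-fold higher number from compound 2 to compound 3 (0.06 log units; within the scatter) is within the scatter, and it rests on the fact that compounds 2 and 3 differ only in the configuration as drawn alone. Compound 4, `CC(=O)OC[C@H]1O[C@@H](n2cc(CN3C(=O)/C(=C/c4ccc(N(C)C)cc4)c4ccccc43)nn2)[C@H](OC(C)=O)[C@@H](OC(C)=O)[C@@H]1OC(C)=O`, differs from compound 3 by dimethylamino in place of hydrogen on an aromatic carbon. For the measured compounds named here, no measured step touches a substituent on that ring; the only step in this assay, a 1.2-fold higher number from compound 2 to compound 3 (0.06 log units; within the scatter), concerns the double bond and gives no direction for the new group. For compound 4 a value of about 15000 nM is therefore expected, within 3000 nM to 60000 nM. That estimate means a step of a 1.4-fold lower number from compound 3 to compound 4 (0.14 log units; within the scatter) of no clear direction beyond the scatter.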

Compound 4, half-maximal inhibitory concentration: 19400 nM
Estimate against measurement, compound 4: 1.3-fold (0.11 log units) below, within the range that was stated.
By their numbers in this assay, from the lowest: compounds 2, 4 and 3 (each within the scatter of the next). At a limit, above all of these: compound 1.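

In this assay, dimethylamino in place of hydrogen on an aromatic carbon, para to a large group, gives a 1.1-fold lower number from compound 3 to compound 4 (0.03 log units; within the scatter). This position therefore tolerates this one group with no readable change in the number, with the double bond drawn E. Nothing at hand bears on a cause for this result. As far as these compounds go, whether the same holds for a carboxylic acid or a nitrile at this place remains open. So does the effect of dimethylamino with the double bond drawn Z, as in compound 2.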